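This account rests on a few compounds, and the source may have more. Where it says the series, first, only, none or still open, it means among the compounds named here.

Measured compounds:
- compound 1, `O=C(NNc1ccccc1C(F)(F)F)C12C3C=CC4C3C3C(C=CC31)C42`: 132000 nM
- compound 2, `O=C(NNc1ccccc1Cl)C12C3CCC4C3C3C(CCC31)C42`: 933000 nM

Of the compounds shown here, two have been measured in an assay on HEK293 cells for antagonist activity at P2X purinoceptor 7 (Homo sapiens), read by fluorescence, with a stated time of 2 h; on this read-out higher numbers stand for weaker inhibition and lower numbers for stronger inhibition. Compound 1 gives 132000 nM, while compound 2 gives 933000 nM. Of these two numbers, compound 2 has the highest, and the gap to compound 1 is beyond the usual scatter of repeated measurements. Compound 1 and compound 2 differ both in the group on the aromatic ring and in the saturation of the shared core, so their two values alone do not show which of the two differences matters.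

Compound 3, `O=C(NNc1ccccc1C(F)(F)F)C12C3CCC4C3C3C(CCC31)C42`, keeps the fully saturated core of compound 2 and changes only the aromatic substituent: trifluoromethyl in place of chloro on an aromatic carbon. Among the measured compounds shown here, no step of this single kind has been measured here. Since compound 1, which carries the same trifluoromethyl group, gives the lower of the two known values, a moderate move towards stronger inhibition is expected for compound 3, that is, a downward step in this assay of a 2.3-fold lower number from compound 2 to compound 3 (0.37 log units; beyond the scatter). Compound 3 is thus estimated at 400000 nM, with a range from 150000 nM to 1200000 nM.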

Compound 3, half-maximal inhibitory concentration: 366000 nM
The estimate for compound 3 lay 1.1-fold (0.04 log units) above the measured number; the measured number falls inside the stated range.
By their numbers in this assay, from the lowest: compound 1; then compound 3; then compound 2.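

In this assay, keeping the saturated core fixed shows that the group on this aromatic carbon matters by itself: trifluoromethyl in place of chloro gives a 2.5-fold lower number from compound 2 to compound 3 (0.41 log units; beyond the scatter). The step is modest but real, so the difference between the first two compounds can no longer be read as a matter of the core alone, although compound 3, at 366000 nM, still sits at a very high number and therefore shows weak inhibition. Nothing available explains why this swap shifts the number, so the result stands as an observation without a known cause.

As far as these compounds go, with only chloro and trifluoromethyl compared at this position on the saturated core, it remains open whether a smaller fluoro group, a methoxy group or an amine would lower the number further or raise it again. From the compounds shown here alone, it is also open whether the same swap would give a step of similar size on the core of compound 1, and how much the saturation of the core contributes in its own right.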